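The source may report more compounds than this note shows. Statements on the series, on what has been measured and on what is new or still open speak of the compounds shown alone.

Compound 1 `Cc1ccccc1-c1c(C(=O)N(C)Cc2ccccc2Cl)n(C)c(=O)c2ccccc12` gives 19 nM in an assay on IM-9 cells for binding affinity to Substance-P receptor (Homo sapiens) (a lower number here means a stronger inhibitor, a higher number a weaker inhibitor), the highest of the three numbers in hand. Compound 3 `Cc1cc2c(-c3ccccc3)c(NC(=O)N(C)Cc3ccccc3Cl)n(C)c(=O)c2cc1C` gives 4.2 nM in this assay, a lower number than compound 1 by a gap beyond the scatter; compound 2 `CN(Cc1cc(C(F)(F)F)cc(C(F)(F)F)c1)C(=O)c1c(-c2ccccc2)c2cccnc2c(=O)n1C` gives 0.25 nM in this assay, the lowest of the three and far below compound 1. Among the compounds with values here, no pair among the measured compounds differs in a single place, so no isolated step can be read off.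

Compound 4 `COc1ccccc1CN(C)C(=O)c1c(-c2ccccc2C)c2ccccc2c(=O)n1C` differs from compound 1 by methoxy in place of chloro on an aromatic carbon, read at the next bond as 2-chlorobenzyl to 2-methoxybenzyl. Nothing in the measured set isolates this change. For compound 4 a small drop in the number is expected, a 1.6-fold lower number from compound 1 to compound 4 (0.20 log units; within the scatter), possibly no more than the scatter; the estimate for compound 4 in this assay is 12 nM, in the range 3 nM to 50 nM.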

Compound 4, half-maximal inhibitory concentration: 16 nM
For compound 4 the middle estimate is 1.3-fold (0.12 log units) below the measured one; measured number inside the range.
By their numbers in this assay, from the lowest: compound 2; then compound 3; then compounds 4 and 1 (each within the scatter of the next).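

In this assay, the change from 2-chlorobenzyl to 2-methoxybenzyl gives a 1.2-fold lower number from compound 1 to compound 4 (0.07 log units; within the scatter), so at this position, methoxy in place of chloro leaves the number within the scatter. The entering methoxy brings a hydrogen-bond acceptor that chloro lacks, and this first isolated step shows no separable difference with it. No evidence in hand bears on why the two groups read alike. From the compounds shown here alone, it remains open whether an amine, a carboxylic acid or a longer chain such as ethoxy would read the same here. Going by these compounds, the step also stands on the core of compound 1 alone, and the same change on other cores remains open.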